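The source may report more compounds than this note shows. Statements on the series, on what has been measured and on what is new or still open speak of the compounds shown alone.

Measured so far:
compound 1, `O=C(Nc1cccnc1)c1ccccc1`: 2%
compound 2, `O=C(Nc1cccnc1)c1ccc(OC(F)(F)F)cc1`: 3%

In an assay on V79 cells for inhibition of cytochrome P450 11B1, mitochondrial (Homo sapiens), tested at 500 nM (on this read-out higher numbers stand for more inhibition at the one concentration tested (going by the name of the read-out) and lower numbers for less inhibition), compound 2 gives 3%, and compound 1 gives 2%; the two numbers lie within the scatter of each other, so neither stands apart. Compound 3, `O=C(Nc1cccnc1)c1ccc(C(F)(F)F)cc1`, carries trifluoromethyl in place of trifluoromethoxy on an aromatic carbon. Among the measured compounds shown here, the only measured step, a number 1 percentage points higher from compound 1 to compound 2 (within the scatter), concerns the same position and stayed within the scatter, so the one change known here at this position did nothing visible. Compound 3 is therefore expected to move by a number 1 percentage points higher from compound 2 to compound 3 (within the scatter), no step beyond the scatter. The estimate for compound 3 is 4%, within a range from 0% to 14%.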

Compound 3, a percentage reported as inhibition, at one concentration (the size of the read-out at that concentration, not a potency): 1%
Compound 3: the middle estimate sits 3 percentage points above what was measured, and the stated range covers the measured number.
By their numbers in this assay, from the lowest: compounds 3, 1 and 2 (each within the scatter of the next).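

With trifluoromethyl at the place para to a group of 9 heavy atoms, this assay shows a number 2 percentage points lower from compound 2 to compound 3 (within the scatter) against trifluoromethoxy and a number 1 percentage points lower from compound 1 to compound 3 (within the scatter) against hydrogen. The position has now carried two different groups, and neither stands apart from hydrogen or from the other. Nothing available bears on why the values stay so close.

Going by these compounds, what an amine or a carboxylic acid at this position would do remains open, as does whether a change elsewhere on the shared core would shift the read-out.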